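Moving the Methyl: From Compound 3 to Compound 4

This account rests on a few compounds, and the source may have more. Where it says the series, first, only, none or still open, it means among the compounds named here.

Compound 3 `COc1ccccc1-n1cc(CN2C(=O)C[C@@H]3CC[C@@]2(C)C3(C)C)nn1` gives the lowest number of the three measured compounds in a functional assay on LoVo cells (Homo sapiens) for inhibition, read by MTT assay, with a stated time of 24 h (a higher number here means a weaker inhibitor, a lower number a stronger inhibitor), at 70 nM. Compound 1 `Cc1ccccc1-n1cc(CN2C(=O)C[C@@H]3CC[C@@]2(C)C3(C)C)nn1` sits closest, at 80 nM, and a 1.1-fold lower number from compound 1 to compound 3 (0.06 log units; within the scatter) lies within the scatter. Compound 2 `CC1(C)[C@H]2CC[C@]1(C)N(Cc1cn(-c3ccccc3O)nn1)C(=O)C2` stands furthest, at 540 nM, with a 7.7-fold lower number from compound 2 to compound 3 (0.89 log units; beyond the scatter). Compound 4 `Cc1ccc(-n2cc(CN3C(=O)C[C@@H]4CC[C@@]3(C)C4(C)C)nn2)cc1` differs from compound 3 by 4-methylphenyl in place of 2-methoxyphenyl on an aromatic nitrogen. Of the measured steps, a 1.1-fold lower number from compound 1 to compound 3 (0.06 log units; within the scatter) shows methyl and methoxy on the aromatic carbon giving indistinguishable numbers, while a 6.8-fold higher number from compound 1 to compound 2 (0.83 log units; beyond the scatter) shows only hydroxy costing potency. Among the compounds with values here, no measured pair tests where the methyl sits on the phenyl. Compound 4 is therefore expected near 100 nM, between 40 nM and 300 nM. That expectation amounts to a 1.4-fold higher number from compound 3 to compound 4 (0.15 log units; within the scatter), a step within the scatter.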

Compound 4, half-maximal inhibitory concentration: 50 nM
Compound 4: the middle estimate sits 2.0-fold (0.30 log units) above what was measured; the range from low to high includes it.
By their numbers in this assay, from the lowest: compounds 4, 3 and 1 (each within the scatter of the next); then compound 2.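

The step of a 1.4-fold lower number from compound 3 to compound 4 (0.15 log units; within the scatter) and the step of a 1.6-fold lower number from compound 1 to compound 4 (0.20 log units; within the scatter) both lie within the scatter, so in this assay 4-methylphenyl on the aromatic nitrogen cannot be told apart from 2-methoxyphenyl or 2-methylphenyl. Only 2-hydroxyphenyl stands apart, as an 11-fold lower number from compound 2 to compound 4 (1.03 log units; beyond the scatter) shows, and the new step is the largest of the set. Nothing given here accounts for these numbers. Still open, going by these compounds, is whether a phenyl ring carrying an amine or a carboxylic acid in place of the methyl would keep numbers like these.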